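Cytotoxicity notes on thiocarbamate-linked amides

The compounds below may be only part of what the source reports. "The series", "measured", "known", "first", "only" and "open" are said of these compounds alone.

Measured so far:
compound 1 `O=C(NCCOC(=S)Nc1ccc([N+](=O)[O-])cc1Cl)c1cccnc1` — > 800000 nM
compound 2 `Cc1ccc(NC(=S)OCCNC(=O)C(C)(C)Oc2ccc(Cl)cc2)cc1` — 771000 nM

In an ADME assay on H9c2 cells (Rattus norvegicus) for cytotoxicity, read by MTT assay, with a stated time of 48 h (on this read-out higher numbers stand for weaker inhibition and lower numbers for stronger inhibition), compound 1 returns only a limit, > 800000 nM, with no number beneath it. For the measured compounds named here, compound 2 gives 771000 nM in this assay, the only number in the set, and it sits near the top of the measured range. Compound 3 `CC(C)(Oc1ccc(Cl)cc1)C(=O)NCCOC(=S)Nc1ccc([N+](=O)[O-])cc1Cl` differs from compound 2 by 2-chloro-4-nitrophenyl in place of 4-methylphenyl on an amide-type nitrogen. Going by the values given here, no measured pair shows a single change of this kind, so the size of the step cannot be read from the data; compound 1 carries the same entering group on the same nitrogen and sits at the limit (the limit of > 800000 nM in this assay, at which 1 of the 2 values shown sits). The step from compound 2 to compound 3 is expected to be no larger than the scatter, a 1.0-fold higher number from compound 2 to compound 3 (0.02 log units; within the scatter). Compound 3 is therefore expected near 800000 nM in this assay, between 400000 nM and 1600000 nM, with a fair chance that only a limit is reported.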

Compound 3, half-maximal inhibitory concentration: > 800000 nM
Compound 3: only a limit was reported (the forecaster's own chance of this, stated with the estimate: 50%); the middle value lies on the limit itself.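

In this assay, 2-chloro-4-nitrophenyl in place of 4-methylphenyl on the amide-type nitrogen carrying the thiocarbonyl carbon gives an at least 1.0-fold higher number from compound 2 to compound 3 (0.01 log units; that floor lies within the scatter). For the compounds shown here, this is the first single change read at this nitrogen, but it is only a floor, and its true size stays unknown. Compound 1 and compound 3 share the 2-chloro-4-nitrophenyl group on this nitrogen but have different amide parts, and both reach the same limit: the limit of > 800000 nM in this assay, at which 2 of the 3 values shown sit.

No step can be read between compound 1 and compound 3, and neither compound gives a number that would show whether the amide part matters when this group is present. As far as these compounds go, it also remains open whether an amine or a carboxylic acid in place of the nitro group would give a number rather than a limit.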